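Furan-2-yl to 1H-pyrrol-3-yl: an expected flat step

The source may report more compounds than this note shows. Statements on the series, on what has been measured and on what is new or still open speak of the compounds shown alone.

- compound 1 `O=C(O)c1ccc(NCc2c(-c3c(Cl)cccc3C(F)(F)F)noc2-c2ccco2)cc1` gives 392000 nM
- compound 2 `O=C(O)c1ccc(NC(=O)c2c(-c3c(Cl)cccc3C(F)(F)F)noc2-c2ccccc2)cc1` gives 490000 nM

In a physicochemical assay for solubility, read by spectrophotometry, measured as kinetic solubility, with a stated time of 90 min, at pH 7.4, tested at 500 uM (on this read-out lower numbers stand for lower solubility and higher numbers for higher solubility), compound 1 gives 392000 nM, within the scatter of compound 2 at 490000 nM. Compound 3 `O=C(O)c1ccc(NCc2c(-c3c(Cl)cccc3C(F)(F)F)noc2-c2cc[nH]c2)cc1` keeps the core of compound 1 and carries 1H-pyrrol-3-yl in place of furan-2-yl on an aromatic carbon. Going by the values given here, no measured pair differs in one place only, so the data give no direct size for this change, and no shift beyond the scatter is expected in this assay. The expected step of a 1.0-fold higher number from compound 1 to compound 3 (0.01 log units; within the scatter) is small. For compound 3 the estimated value is 400000 nM, with an expected range from 250000 nM to 500000 nM.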

Compound 3, solubility: 411000 nM
Compound 3: the middle estimate sits 1.0-fold (0.01 log units) below what was measured; measured number inside the range.
By their numbers in this assay, from the lowest: compounds 1, 3 and 2 (each within the scatter of the next).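

In this assay, going by these compounds alone, the one step available at this position is small (a 1.0-fold higher number from compound 1 to compound 3 (0.02 log units; within the scatter)). On this aromatic carbon next to the ring oxygen, 1H-pyrrol-3-yl in place of furan-2-yl brings a hydrogen-bond donor and removes a hydrogen-bond acceptor, yet the read-out stays within the scatter. Nothing measured here gives a reason for this result.

Open, as far as these compounds go, is whether a group carrying an amine, such as aminomethyl, or a longer alkyl chain at this position would read beyond the scatter in this assay on the core of compound 1.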